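The compounds below may be only part of what the source reports. "The series", "measured", "known", "first", "only" and "open" are said of these compounds alone.

This piece follows a step among close relatives of compound 1 `C=CCNc1nc(N)c(C(=O)N=C(N)N)nc1Cl`, which in an assay for inhibition of acid-sensing ion channel 3 (Homo sapiens), read by patch clamp, tested at 1 uM (on this read-out lower numbers stand for less inhibition and higher numbers for more inhibition at the one concentration tested (going by the name of the read-out)), gives 16%. Compound 2 `NC(N)=NC(=O)c1nc(Cl)c(N2CCCCC2)nc1N` is recorded in this assay as "not determined" (no result reported), and compound 3 `NC(N)=NC(=O)c1nc(Cl)c(Nc2ccccn2)nc1N` likewise as "not determined" (no result reported), so compound 3 stands without any number to lean on. Compound 4 `NC(N)=NC(=O)c1nc(Cl)c(Oc2ccccc2)nc1N` is the next relative: it differs from compound 3 by phenoxy in place of (pyridin-2-yl)amino on an aromatic carbon. For the measured compounds named here, no measured pair shows what such a change does here, and the scatter of this assay is wide, so only a small step in either direction, or none beyond the scatter, can be expected, with the single number from compound 1 as the nearest anchor. Compound 4 is therefore expected to give about 20%, within a range from 0% to 45%.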

Compound 4, a percentage reported as inhibition, at one concentration (the size of the read-out at that concentration, not a potency): 23%
Beside the measured number, compound 4's estimate is 3 percentage points below it; measured number inside the range.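

In this assay, putting phenoxy in place of allylamino on the shared core gives a number 7 percentage points higher from compound 1 to compound 4 (within the scatter), so this read-out does not separate the two groups, even though one is joined through oxygen and the other through nitrogen. The steps to compound 2 and compound 3 cannot be read, as neither has a number. No measured property bears on this result.

As far as these compounds go, whether a methoxy group, a dimethylamino group or a longer chain at this place would move the inhibition beyond the scatter remains open.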